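The source may hold more compounds than are shown below. What is called first, only, known or untested is meant among the compounds shown, and "the series" means these compounds.

Measured compounds:
compound 1 `CCC(c1ccccc1)c1nc(-c2ccc(Cl)cc2)c(CC(=O)O)s1` — 190 nM
compound 2 `O=C(O)Cc1sc(C(c2ccc(F)cc2)c2ccc(F)cc2)nc1-c1cccc(F)c1` — 1.4 nM

In an in vitro assay on HEK385-7 cells for displacement of a labelled ligand from prostaglandin D2 receptor 2 (Homo sapiens) (on this read-out lower numbers stand for stronger inhibition and higher numbers for weaker inhibition), compound 1 gives 190 nM, while compound 2 gives 1.4 nM. Going by the values given here, compound 2 therefore stands lowest of the two numbers, with compound 1 as the only neighbour, and that gap lies beyond the scatter.

Compound 3 `N#Cc1ccc(-c2nc(C(c3ccc(F)cc3)c3ccc(F)cc3)sc2CC(=O)O)cc1` is not yet measured. Against compound 2 it shows (4-cyanophenyl in place of 3-fluorophenyl on an aromatic carbon). Among the compounds with values here, no measured pair carries this change, so its size is open; a shift of modest size, within or a little beyond the scatter, is expected, a higher number being somewhat more plausible than a lower one. The step from compound 2 to compound 3 is expected to be a 2.1-fold higher number from compound 2 to compound 3 (0.33 log units; beyond the scatter). For compound 3 in this assay the estimate is 3 nM, within a range of 0.8 nM to 12 nM.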

Compound 3, half-maximal inhibitory concentration: 150 nM
Estimate against measurement, compound 3: 50-fold (1.70 log units) below, outside the stated range (above it).
By their numbers in this assay, from the lowest: compound 2; then compounds 3 and 1 (each within the scatter of the next).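

In this assay the aromatic carbon next to the ring nitrogen proves far from tolerant: 4-cyanophenyl in place of 3-fluorophenyl gives a 110-fold higher number from compound 2 to compound 3 (2.03 log units; beyond the scatter) with the rest of the structure unchanged. This single step is large and beyond the scatter, so the substituent at this position has a strong bearing on the read-out. No measured information on the compounds explains the loss.

From the compounds shown here alone, the step changes both the substituent and its place on the phenyl ring, so the contribution of each remains open. A 3-cyanophenyl or 4-fluorophenyl group at this carbon would separate the two.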